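Hydroxymethyl for Carbamoyl: Expected Cytotoxicity of Compound 3

A few compounds are considered here, and "the series" means these few. Any claim that something is new, unique, unknown or untested is made for them only; others in the source may bear on it.

Measured compounds:
Compound 1 `Cc1cc(CCC#N)cc(C)c1Oc1cc(Nc2ccc(C#N)cc2)c(N)cc1C(N)=O`: in an ADME assay on TZM cells (Homo sapiens) for cytotoxicity, read by XTT assay, with a stated time of 4 days (a higher number here means that more compound is tolerated, a lower number that less compound is tolerated), compound 1 gives > 9400 nM, a limit of the assay rather than a number.
Compound 2 `Cc1cc(/C=C/C#N)cc(C)c1Oc1cc(Nc2ccc(C#N)cc2)c(N)cc1C(N)=O`: in this assay compound 2 gives > 23600 nM, also a limit of the assay.

Compound 1 therefore stands only at a limit, and the other value shown is a limit as well, so no order between the two can be read. Among the measured compounds shown here, the single measured step, a step that the two limits leave unreadable from compound 1 to compound 2, cannot be sized because the limit of > 23600 nM in this assay, at which 1 of the 2 values shown sits, and the limit of > 9400 nM in this assay, at which 1 of the 2 values shown sits, cap both values.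

Compound 3 `Cc1cc(CCC#N)cc(C)c1Oc1cc(Nc2ccc(C#N)cc2)c(N)cc1CO` differs from compound 1 by hydroxymethyl in place of carbamoyl on an aromatic carbon. For the measured compounds named here, no measured step touches this change, so nothing points to a shift beyond the scatter in either direction. Compound 3 is expected at 15000 nM, within 5000 nM to 50000 nM. The step that the limit leaves unreadable from compound 1 to compound 3 is thus estimated to stay within the scatter.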

Compound 3, half-maximal cytotoxic concentration in the TZM assay: > 23800 nM
Compound 3 ended at the assay's limit (the forecaster's own chance of this, stated with the estimate: 70%); at least 1.5-fold (0.20 log units) between middle value and limit.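

Among the compounds shown here, compound 1 and compound 3 both stand at limits of the TZM assay, so no step between them can be read. In a physicochemical assay for lipophilicity, at pH 7.4 (a higher number here means a more lipophilic compound, a lower number a more polar compound), compound 1 gives 2.65 and compound 3 gives 3.68. The compounds shown leave open where the tolerated concentration of either compound actually lies.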